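Shrinking the amine-bearing side chain on the shared core

The compounds below may be only part of what the source reports. "The series", "measured", "known", "first", "only" and "open" are said of these compounds alone.

Two compounds share one core and differ only in the side chain attached to a ring nitrogen. Compound 1 `CN[C@H](CC(C)C)Cn1c(=O)c(-c2cccc(OC)c2F)c(C)n(Cc2c(F)cccc2F)c1=O` carries a 3-methyl-1-(methylamino)butyl group there, and in an assay on HEK293 cells for binding affinity to Gonadotropin-releasing hormone receptor (Homo sapiens), read by radioligand binding (on this read-out higher numbers stand for weaker inhibition and lower numbers for stronger inhibition), compound 1 gives 1.2 nM. Compound 2 `COc1cccc(-c2c(C)n(Cc3c(F)cccc3F)c(=O)n(C[C@@H](C3CCCCC3)N(C)C)c2=O)c1F` carries a cyclohexyl(dimethylamino)methyl group instead; in this assay compound 2 gives 4.1 nM, the highest of the two numbers, with a 3.4-fold higher number from compound 1 to compound 2 (0.53 log units; beyond the scatter) separating them. Compound 3 `COc1cccc(-c2c(C)n(Cc3c(F)cccc3F)c(=O)n(C[C@@H](N)C(C)C)c2=O)c1F` continues at the same spot: 1-amino-2-methylpropyl in place of cyclohexyl(dimethylamino)methyl on a saturated chain carbon bound to an aromatic nitrogen. Among the measured compounds shown here, the only step that bears on this is the one from compound 1 to compound 2, which shows that reshaping this side chain moves the number modestly rather than drastically. Since compound 3 removes the ring and one methyl group, a modest shift toward a lower number is expected, a 1.6-fold lower number from compound 2 to compound 3 (0.21 log units; within the scatter). The estimate for compound 3 in this assay is 2.5 nM, within 0.7 nM to 10 nM.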

Compound 3, inhibition constant: 973 nM
Compound 3: middle estimate off by 390-fold (2.59 log units), on the low side; the measured number lies above the stated range.
By their numbers in this assay, from the lowest: compound 1; then compound 2; then compound 3.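

This side chain tolerates much less change than the first two compounds suggested: in this assay there is a 240-fold higher number from compound 2 to compound 3 (2.38 log units; beyond the scatter), and an 810-fold higher number from compound 1 to compound 3 (2.91 log units; beyond the scatter). Both large steps end at 1-amino-2-methylpropyl, the smallest of the three groups and the only one whose nitrogen carries no methyl group, so affinity here depends sharply on what sits on this saturated chain carbon bound to an aromatic nitrogen. No available measurement explains the loss.

The compounds shown change the carbon part of the side chain and the substitution on its nitrogen together, so the effect of each alone stays unknown. A 1-(dimethylamino)-2-methylpropyl group would keep the chain of compound 3 while restoring the methyl groups on nitrogen, and would help separate the two changes.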